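Removing a benzyl ether from a coumarin chalcone

A few compounds are considered here, and "the series" means these few. Any claim that something is new, unique, unknown or untested is made for them only; others in the source may bear on it.

Among the compounds with values here, compound 1 `COc1cccc(COc2ccc3cc(C(=O)/C=C/c4cccc(OC)c4OC)c(=O)oc3c2)c1` is the only member of this set with a number attached. In a functional assay on MCF7 cells (Homo sapiens) for cytotoxicity, read by MTT assay, with a stated time of 72 h (on this read-out higher numbers stand for weaker inhibition and lower numbers for stronger inhibition), compound 1 gives 35100 nM, a weak result on this scale. Compound 2 `COc1cccc(COc2ccc3cc(C(=O)/C=C/c4ccc(Cl)cc4Cl)c(=O)oc3c2)c1` shares the same core but carries two chlorines on the outer ring; in this assay compound 2 stands as "not determined" (no result reported), so it offers no comparison.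

Compound 3 `COc1cccc(/C=C/C(=O)c2cc3ccc(O)cc3oc2=O)c1OC` differs from compound 1 in a single spot: hydrogen in place of 3-methoxybenzyl on an oxygen on an aromatic ring. In other words, the (3-methoxybenzyl)oxy group becomes a hydroxy group, and everything else is kept.

Within the data shown here, no pair of measured compounds shows what such a change does here, so the expectation rests on compound 1 alone. A small drift toward weaker inhibition is expected, with a real chance that the step from compound 1 to compound 3, estimated at a 1.6-fold higher number from compound 1 to compound 3 (0.20 log units; within the scatter), stays within the usual scatter. Compound 3 is therefore expected to give about 55000 nM in this assay, estimated between 15000 nM and 160000 nM.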

Compound 3, half-maximal inhibitory concentration: 16600 nM
For compound 3 the middle estimate is 3.3-fold (0.52 log units) above the measured one, within the range that was stated.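

Replacing the (3-methoxybenzyl)oxy group with a hydroxy group does not weaken the result in this assay but gives a 2.1-fold lower number from compound 1 to compound 3 (0.33 log units; beyond the scatter) and this modest step lies beyond the usual scatter. For this pair, then, the 3-methoxybenzyl group on the oxygen is not needed for the cytotoxicity seen, although compound 3 at 16600 nM still needs a high concentration to act on these cells. No measurement at hand explains why the number falls with this change.

The compounds shown leave open whether any group on this oxygen would do the same, or whether the free hydroxy group matters: a methyl ether, a longer alkyl chain or a chain ending in an amine at this spot would help to tell these cases apart. They also leave open whether the same change would hold with a different outer ring, such as the two chlorines of compound 2, which has no number to compare.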